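Benzyloxy isoflavone series: trifluoromethyl position shift

The compounds below may be only part of what the source reports. "The series", "measured", "known", "first", "only" and "open" are said of these compounds alone.

Measured so far in a functional assay on HepG2 cells (Homo sapiens) for antiproliferative activity, read by MTT assay, with a stated time of 24 h; a lower number here means a stronger inhibitor, a higher number a weaker inhibitor:
compound 1 `COc1cc(OC)c(-c2coc3cc(OCc4ccc([N+](=O)[O-])cc4)ccc3c2=O)cc1OC` gives 2500 nM
compound 2 `COc1cc(OC)c(-c2coc3cc(OCc4ccccc4C(F)(F)F)ccc3c2=O)cc1OC` gives 6550 nM
compound 3 `COc1cc(OC)c(-c2coc3cc(OCc4cccc(F)c4)ccc3c2=O)cc1OC` gives 1230 nM

Compound 2 gives the highest number of the three. The steps to the others are beyond the scatter: a 2.6-fold higher number from compound 1 to compound 2 (0.42 log units; beyond the scatter) and a 5.3-fold lower number from compound 2 to compound 3 (0.73 log units; beyond the scatter), while a 2.0-fold lower number from compound 1 to compound 3 (0.31 log units; beyond the scatter).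

Compound 4 `COc1cc(OC)c(-c2coc3cc(OCc4ccc(C(F)(F)F)cc4)ccc3c2=O)cc1OC` differs from compound 2 only by 4-(trifluoromethyl)phenyl in place of 2-(trifluoromethyl)phenyl on a saturated chain carbon bound to an oxygen on an aromatic ring. For the measured compounds named here, no measured step makes this exact change. The nearest bearing is that compound 1, which also carries a group on a saturated chain carbon bound to an oxygen on an aromatic ring, sits lower than compound 2, as does compound 3. Compound 4 is therefore expected to give a lower number than compound 2, a step of about a 2.6-fold lower number from compound 2 to compound 4 (0.42 log units; beyond the scatter). The estimate for compound 4 is 2500 nM, expected within 1000 nM to 6500 nM.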

Compound 4, half-maximal inhibitory concentration: 890 nM
For compound 4 the middle estimate is 2.8-fold (0.45 log units) above the measured one; measured number below the stated range.
By their numbers in this assay, from the lowest: compounds 4 and 3 (each within the scatter of the next); then compound 1; then compound 2.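

With a 7.4-fold lower number from compound 2 to compound 4 (0.87 log units; beyond the scatter) in this assay on the same atoms, the place of the trifluoromethyl on the phenyl alone carries a clear difference. Against the nitro group, a 2.8-fold lower number from compound 1 to compound 4 (0.45 log units; beyond the scatter) comes with trifluoromethyl, whereas a 1.4-fold lower number from compound 3 to compound 4 (0.14 log units; within the scatter) leaves 4-(trifluoromethyl)phenyl and 3-fluorophenyl inseparable on this saturated chain carbon. Still open, on these data alone, is whether an amine or a carboxylic acid in place of the trifluoromethyl, or a longer chain in place of the saturated chain carbon, would keep these numbers. No supporting measurement accounts for these differences.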